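This account rests on a few compounds, and the source may have more. Where it says the series, first, only, none or still open, it means among the compounds named here.

Measured so far in an assay on isolated protein for displacement of a labelled ligand from Orexin/Hypocretin receptor type 1 (Homo sapiens), with a stated time of 90 min; on this read-out higher numbers stand for weaker inhibition and lower numbers for stronger inhibition:
compound 1 `COc1cc(F)c(CN2C(=O)N(c3cc(OC)nc(OC)c3)S(=O)(=O)c3ccccc32)c(F)c1` — 1 nM
compound 2 `COc1cc(F)c(CN2C(=O)N(c3ccc(OC)c(OC)c3)S(=O)(=O)c3ccccc32)c(Cl)c1` — 0.398 nM
compound 3 `COc1cc(F)c(CN2C(=O)N(c3ccc(OC)c(OC)c3)S(=O)(=O)c3ccccc32)c(F)c1` — 2 nM

Compound 2 stands lowest of the three numbers in this assay; its steps to compound 1 and to compound 3 are both beyond the scatter, so it is the most potent of the measured set. The two measured steps are a 2.0-fold higher number from compound 1 to compound 3 (0.30 log units; within the scatter) and a 5.0-fold higher number from compound 2 to compound 3 (0.70 log units; beyond the scatter); the first lies within the scatter, the second is a modest but real loss on going from chloro to fluoro.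

Compound 4 `COc1ccc(N2C(=O)N(Cc3c(F)cccc3Cl)c3ccccc3S2(=O)=O)cc1OC` differs from compound 2 in one place: hydrogen in place of methoxy on an aromatic carbon. For the measured compounds named here, the methoxy that leaves is common to all three measured compounds, so neither measured step bears directly on this change; the only guide is that compound 2 is the best starting point available, and that a substituent shared by every measured compound is removed. Some loss is expected, so for compound 4 the expected step is a 5.0-fold higher number from compound 2 to compound 4 (0.70 log units; beyond the scatter), a rise in the number. The estimate for compound 4 in this assay is 2 nM, with a range from 0.4 nM to 10 nM.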

Compound 4, inhibition constant: 7.94 nM
Compound 4: middle estimate off by 4.0-fold (0.60 log units), on the low side, within the range that was stated.
By their numbers in this assay, from the lowest: compound 2; then compounds 1 and 3 (each within the scatter of the next); then compound 4.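

Within this assay, removing the methoxy from the 2-chloro-6-fluoro-4-methoxybenzyl group gives a 20-fold higher number from compound 2 to compound 4 (1.30 log units; beyond the scatter) and is the first measured change at this position, which shows that the group's presence matters strongly to the number in this series. Replacing the 2,6-difluoro-4-methoxyphenyl group with 2-chloro-6-fluorophenyl gives a 4.0-fold higher number from compound 3 to compound 4 (0.60 log units; beyond the scatter) and so shows that the chloro present in compound 4 does not offset the missing methoxy. No measurement at hand explains the loss.

As far as these compounds go, whether a hydroxy, an ethoxy or a methyl group at this place would keep the number close to that of compound 2 remains open. Also open, from the compounds shown here alone, is whether the same loss would appear with the 2,6-dimethoxypyridin-4-yl group of compound 1 on the amide-type nitrogen.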